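A few compounds are considered here, and "the series" means these few. Any claim that something is new, unique, unknown or untested is made for them only; others in the source may bear on it.

For the measured compounds named here, in a physicochemical assay for solubility, measured as kinetic solubility (a higher number here means a more soluble compound, a lower number a less soluble compound), compound 1 `Cc1cc(C)c(CN2CCc3c(Cl)cc([C@H](CO)[C@H]4CCCO4)c(Cl)c3C2=O)c(=O)[nH]1` gives 430000 nM, the only single number available so far. Compound 2 `Cc1cc(C)c(CN2CCc3c(Cl)cc(C(CO)c4ccon4)c(Cl)c3C2=O)c(=O)[nH]1`, which carries a different group on the shared core, gives 596000 nM; 481000 nM (2 entries) across its two entries, and these values lie within the usual scatter of the value for compound 1. Compound 3 `Cc1cc(C)c(CN2CCc3c(Cl)cc([C@@H](CO)[C@@H]4CCOC4)c(Cl)c3C2=O)c(=O)[nH]1` has the same atoms as compound 1, joined differently: a group of 8 heavy atoms (6 carbon, 2 oxygen; one five-membered non-aromatic ring with 1 hetero atom) in place of a group of 8 heavy atoms (6 carbon, 2 oxygen; one five-membered non-aromatic ring with 1 hetero atom), on an aromatic carbon, on an aromatic carbon. Going by the values given here, no measured pair shows this change directly, so the expectation in this assay is for no step beyond the scatter, in either direction. The expected change is an estimated step of a 1.0-fold higher number from compound 1 to compound 3 (0.02 log units; within the scatter). Compound 3 is expected to give 450000 nM, with an estimated range of 250000 nM to 650000 nM.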

Compound 3, solubility: 537000 nM
Compound 3: middle estimate off by 1.2-fold (0.08 log units), on the low side; low and high end bracket the measured number.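

In this assay, the step is a 1.2-fold higher number from compound 1 to compound 3 (0.10 log units; within the scatter), so the two compounds do not separate. At this position, on an aromatic carbon ortho to a chloro group, one group with a five-membered non-aromatic ring with 1 hetero atom can thus be exchanged for an isomeric group of the same description, joined differently and with 2 defined stereocentres, without the number leaving the scatter. The step is about as large as the spread between repeat entries of a single compound: the several entries of compound 2 in this assay, 596000 nM; 481000 nM (2 entries)

The compounds shown leave open whether any group at this position would give a step beyond the scatter, for example a ring carrying an amine or a carboxylic acid. They also do not separate the effect of the ring's point of attachment from that of its stereochemistry, since the two differ together here.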